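The source may report more compounds than this note shows. Statements on the series, on what has been measured and on what is new or still open speak of the compounds shown alone.

Compound 1 `O=C(/C=C/CCCCCCCCCCBr)CC(O)CCCCCCCCCCBr` gives 30000 nM in a functional assay on SW1573 cells (Homo sapiens) for antiproliferative activity, read by sulforhodamine B assay, with a stated time of 48 h; on this read-out lower numbers stand for stronger inhibition of growth and higher numbers for weaker inhibition of growth.
Compound 2 `C/C(=C\CC(C)C)C(=O)c1ccccc1` gives > 100000 nM in this assay; this is a limit of the assay and not a number.

Compound 2 therefore stands at the edge of what this assay reports, (the limit of > 100000 nM in this assay, at which 1 of the 2 values shown sits), while compound 1 carries a number. Compound 3 `CC(C)C/C=C(\CO)C(=O)c1ccccc1` differs from compound 2 by hydroxy in place of hydrogen on a saturated chain carbon bound to a double-bonded chain carbon. No step between measured compounds is shown, so the effect of this change is open; a modest move towards stronger growth inhibition in this assay is expected, possibly not beyond the scatter. Compound 3 is expected near 60000 nM, between 15000 nM and 100000 nM. The expected step is an at least 1.6-fold lower number from compound 2 to compound 3 (0.22 log units; that floor lies within the scatter).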

Compound 3, concentration for 50% growth inhibition: 24000 nM
Compound 3: middle estimate off by 2.5-fold (0.40 log units), on the high side, and the stated range covers the measured number.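

In this assay, hydroxy in place of hydrogen on a saturated chain carbon bound to a double-bonded chain carbon produces a step that clears the scatter: an at least 4.1-fold lower number from compound 2 to compound 3 (0.61 log units; beyond the scatter). Going by these compounds alone, this is the first sign that this position responds to a change at all. Compound 2 stands at a limit of the assay and not at a number, so the step is only a floor: the limit of > 100000 nM in this assay, at which 1 of the 3 values shown sits.

The compounds shown leave open whether a methoxy, an amine or a carboxylic acid on this carbon would match hydroxy. They also leave open whether a longer chain carrying the hydroxy would keep the step.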